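Trimming an Ethyl Chain: From Compound 1 to Compound 4

A few compounds are considered here, and "the series" means these few. Any claim that something is new, unique, unknown or untested is made for them only; others in the source may bear on it.

Compound 1, `CCc1ccccc1-c1nc(N)nc(N)n1`: 20%
Compound 2, `Nc1nc(N)nc(-c2c(Cl)cccc2Cl)n1`: 54%
Compound 3, `Nc1nc(N)nc(-c2ccc(Cl)cc2Br)n1`: 96%

Three compounds that share a core were tested in a functional assay on the whole organism with Rattus norvegicus as the target, at a dose of 20 mg/kg by the intraperitoneal route; on this read-out higher numbers stand for more inhibition at the one dose given (going by the name of the read-out) and lower numbers for less inhibition. Compound 1 gives 20%, the lowest of the three. Compound 2 gives 54% and compound 3 gives 96%, each lying beyond the scatter above compound 1. Compound 4, `Cc1ccccc1-c1nc(N)nc(N)n1`, differs from compound 1 in one place: hydrogen in place of methyl on a saturated chain carbon bound to an aromatic carbon. Among the measured compounds shown here, no two measured compounds differ in a single place, so the data give no direct guide to how a trim of this size moves the read-out. In this assay a step of no more than the usual scatter, in either direction, is expected. Compound 4 is therefore estimated at 20%, within 0% to 50%. The expected step is no change at the digits printed from compound 1 to compound 4 (within the scatter).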

Compound 4, a percentage reported as inhibition, in the whole organism at one dose (the size of the read-out at that dose, not a potency): 28%
Beside the measured number, compound 4's estimate is 8 percentage points below it; the measured number falls inside the stated range.
By their numbers in this assay, from the lowest: compounds 1 and 4 (each within the scatter of the next); then compound 2; then compound 3.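

Among the compounds shown here, the step from ethyl to methyl is the first comparison here between compounds that differ in one place: in this assay it reads a number 8 percentage points higher from compound 1 to compound 4 (within the scatter). At this position, then, the read-out cannot tell the shorter chain from the longer one. Nothing measured on these compounds offers an explanation for this result.

From the compounds shown here alone, whether a longer chain, an amine or a carboxylic acid at this place would give a step beyond the scatter remains open. Also open, going by these compounds, is whether the same trim would read alike with other groups on the shared core.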